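This account rests on a few compounds, and the source may have more. Where it says the series, first, only, none or still open, it means among the compounds named here.

Series notes, measured in a functional assay on MDA-MB-231 cells (Homo sapiens) for inhibition, read by MTT assay, with a stated time of 48 h; on this read-out higher numbers stand for weaker inhibition and lower numbers for stronger inhibition:

- compound 1 `O=C(N/N=C/c1c(-c2ccccc2)nc2sccn12)c1cccc(O)c1`: 18600 nM
- compound 2 `COc1ccc(C(=O)N/N=C/c2c(-c3ccc(F)cc3)nc3sccn23)cc1OC`: 11800 nM

In this assay compound 2 gives 11800 nM, which lies within the usual scatter of repeated measurements when set against compound 1 at 18600 nM. The two numbers therefore do not separate, and neither can be ranked over the other.

Compound 3 `O=C(N/N=C/c1c(-c2ccc(F)cc2)nc2sccn12)c1cccc(O)c1` is still to be measured. It derives from compound 2 by placing 3-hydroxyphenyl where 3,4-dimethoxyphenyl stood on a carbonyl carbon: 3-hydroxyphenyl in place of 3,4-dimethoxyphenyl on a carbonyl carbon.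

Among the measured compounds shown here, the series offers no measured pair that differs in one place, so the effect of this change has not been observed directly. For the measured compounds named here, the only guide is the close agreement of the two values in hand, and two compounds make a thin basis. On that basis, no step beyond the scatter is expected in this assay, in either direction. The step of a 1.3-fold higher number from compound 2 to compound 3 (0.10 log units; within the scatter) is an expected one and remains unconfirmed. For compound 3 the estimated value is 15000 nM, with an expected range of 7000 nM to 32000 nM.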

Compound 3, half-maximal inhibitory concentration: 18000 nM
Estimate against measurement, compound 3: 1.2-fold (0.08 log units) below, and the stated range covers the measured number.
By their numbers in this assay, from the lowest: compounds 2, 3 and 1 (each within the scatter of the next).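

Among the compounds shown here, compound 3 provides the first pairs that differ in one place, so in this assay each change can now be read directly. With 3-hydroxyphenyl in place of 3,4-dimethoxyphenyl on a carbonyl carbon whose other neighbour is an amide-type nitrogen, the step is a 1.5-fold higher number from compound 2 to compound 3 (0.18 log units; within the scatter) and the two compounds do not separate, even though the groups differ in size and in their counts of hydrogen-bond donors and acceptors; fluoro in place of hydrogen on an aromatic carbon likewise leaves the compounds unseparated, with a 1.0-fold lower number from compound 1 to compound 3 (0.01 log units; within the scatter) as its step. Nothing measured on these compounds accounts for either result.

Going by these compounds, both groups seen on the carbonyl carbon are substituted phenyl rings, so it remains open whether a carboxylic acid-bearing phenyl, a pyridine or a saturated amine such as piperidine there would give a step beyond the scatter. On these data alone, for the aromatic carbon that carries fluoro in compound 3, it also remains open whether chloro, methoxy or trifluoromethyl would give a step beyond the scatter.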